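Free Acid and Larger Side Chain on the Amide Nitrogen

A few compounds are considered here, and "the series" means these few. Any claim that something is new, unique, unknown or untested is made for them only; others in the source may bear on it.

Compound 1, `CCn1c(C(=O)N[C@@H](C)C(=O)OC)ccc1C(CC)(CC)c1ccc(OCS(=O)(=O)c2ccccc2)c(C)c1`: 17900 nM
Compound 2, `CCn1c(C(=O)N[C@H](C)C(=O)OC)ccc1C(CC)(CC)c1ccc(OCS(=O)(=O)c2ccccc2)c(C)c1`: > 50000 nM (a limit of the assay)
Compound 3, `CCn1c(C(=O)N[C@H](C)C(=O)O)ccc1C(CC)(CC)c1ccc(OCS(=O)(=O)c2ccccc2)c(C)c1`: 20100 nM

In a functional assay on BXPC-3 cells (Homo sapiens) for antiproliferative activity, read by MTT assay, with a stated time of 24 h (on this read-out lower numbers stand for stronger inhibition and higher numbers for weaker inhibition), compound 1 gives the lowest number of the two that are numbers; compound 3 sits closest, a step of a 1.1-fold higher number from compound 1 to compound 3 (0.05 log units; within the scatter), within the scatter. Compound 2 reports only a limit, (the limit of > 50000 nM in this assay, at which 1 of the 3 values shown sits); its step from compound 1 is an at least 2.7-fold higher number from compound 1 to compound 2 (0.44 log units; beyond the scatter). Compound 4, `CCn1c(C(=O)N[C@H](C(=O)O)C(C)C)ccc1C(CC)(CC)c1ccc(OCS(=O)(=O)c2ccccc2)c(C)c1`, differs from compound 1 by 1-carboxy-2-methylpropyl in place of 1-(methoxycarbonyl)ethyl on an amide-type nitrogen. Going by the values given here, the step from compound 1 to compound 3 bears on the ester-to-acid part of this change and was within the scatter; the larger side chain has no measured counterpart. Compound 4 is therefore expected near compound 1, with a 1.1-fold higher number from compound 1 to compound 4 (0.05 log units; within the scatter), and its estimated value is 20000 nM (range 8000 nM to 50000 nM).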

Compound 4, half-maximal inhibitory concentration: 16200 nM
For compound 4 the middle estimate is 1.2-fold (0.09 log units) above the measured one; measured number inside the range.
By their numbers in this assay, from the lowest: compounds 4, 1 and 3 (each within the scatter of the next). At a limit, above all of these: compound 2.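

In this assay, the larger 1-carboxy-2-methylpropyl on the amide-type nitrogen leaves the number within the scatter of the smaller 1-carboxyethyl (a 1.2-fold lower number from compound 3 to compound 4 (0.09 log units; within the scatter)). The same holds against the 1-(methoxycarbonyl)ethyl group (a 1.1-fold lower number from compound 1 to compound 4 (0.04 log units; within the scatter)), so this position accepts the added carbons without a readable change. Going by these compounds alone, the only new step beyond the scatter (an at least 3.0-fold lower number from compound 2 to compound 4 (0.48 log units; beyond the scatter)) rests on a value that is a limit of the assay, not a number: the limit of > 50000 nM in this assay, at which 1 of the 4 values shown sits. As far as these compounds go, whether a benzyl side chain or a primary amide in place of the carboxylic acid would move the number remains open.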